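The compounds below may be only part of what the source reports. "The series", "measured", "known", "first", "only" and "open" are said of these compounds alone.

Compound 1 `O=C(Oc1ccc([N+](=O)[O-])cc1)N1CCN(S(=O)(=O)c2ccc(-c3ccccc3)cc2)CC1`: 437 nM
Compound 2 `CCCCc1ccc(S(=O)(=O)N2CCN(C(=O)Oc3ccc([N+](=O)[O-])cc3)CC2)cc1`: 179 nM
Compound 3 `O=C(Oc1ccc([N+](=O)[O-])cc1)N1CCN(S(=O)(=O)c2ccc(Oc3ccc(Cl)c(Cl)c3)cc2)CC1`: 317 nM

Among these three numbers in an assay on isolated protein for inhibition of Fatty-acid amide hydrolase 1 (Homo sapiens), read by fluorescence (on this read-out lower numbers stand for stronger inhibition and higher numbers for weaker inhibition), compound 3 stands second highest. Its nearest neighbour is compound 1, and the step of a 1.4-fold lower number from compound 1 to compound 3 (0.14 log units; within the scatter) lies within the scatter; the step of a 1.8-fold higher number from compound 2 to compound 3 (0.25 log units; within the scatter) also lies within the scatter. Within the data shown here, the only step that went beyond the scatter, a 2.4-fold lower number from compound 1 to compound 2 (0.39 log units; beyond the scatter), concerns an exchange of butyl for phenyl, not a change of the aryl ether.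

Compound 4 `O=C(Oc1ccc([N+](=O)[O-])cc1)N1CCN(S(=O)(=O)c2ccc(Oc3ncc(C(F)(F)F)cc3Cl)cc2)CC1` differs from compound 3 by 3-chloro-5-(trifluoromethyl)pyridin-2-yl in place of 3,4-dichlorophenyl on an oxygen on an aromatic ring. Among the measured compounds shown here, no measured step reproduces this exchange. For the measured compounds named here, the steps that bear on it are those in which the group on the same aromatic carbon was altered: a 1.4-fold lower number from compound 1 to compound 3 (0.14 log units; within the scatter) and a 1.8-fold higher number from compound 2 to compound 3 (0.25 log units; within the scatter) both stayed within the scatter, which suggests that this assay tolerates varied groups at that position without a large shift. Since the new group keeps the aryl ether and alters only the distal ring, the expected step from compound 3 to compound 4 is a 1.1-fold lower number from compound 3 to compound 4 (0.02 log units; within the scatter), that is, none beyond the scatter. For compound 4 the estimate in this assay is therefore 300 nM, with a range from 120 nM to 800 nM.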

Compound 4, half-maximal inhibitory concentration: 2950 nM
Compound 4: middle estimate off by 9.8-fold (0.99 log units), on the low side; the measured number lies above the stated range.
By their numbers in this assay, from the lowest: compounds 2, 3 and 1 (each within the scatter of the next, the first and the last beyond it); then compound 4.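

In this assay, the group on the oxygen on an aromatic ring proved far from freely exchangeable: with 3-chloro-5-(trifluoromethyl)pyridin-2-yl in place of 3,4-dichlorophenyl, the result was a 9.3-fold higher number from compound 3 to compound 4 (0.97 log units; beyond the scatter) and the aryl ether itself stayed in place. Among these compounds, compound 4 also stands apart from the other two compounds, with a 16-fold higher number from compound 2 to compound 4 (1.22 log units; beyond the scatter) and a 6.8-fold higher number from compound 1 to compound 4 (0.83 log units; beyond the scatter) while the largest step among the earlier compounds was only a 2.4-fold lower number from compound 1 to compound 2 (0.39 log units; beyond the scatter), so what is attached to the ether oxygen can matter more than the earlier exchanges on the aromatic carbon suggested. No measurement shown here accounts for this loss of inhibition.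

The exchange brings in a ring nitrogen and a trifluoromethyl group and removes one chlorine all at once, and the compounds shown do not separate these changes. Going by these compounds, it remains open which of them carries the shift, something a plain pyridin-2-yl on the same oxygen, or a carbon-only phenyl ring bearing one chlorine and one trifluoromethyl group, could begin to settle.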